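Chain truncation at the ring substituent of compound 1

A few compounds are considered here, and "the series" means these few. Any claim that something is new, unique, unknown or untested is made for them only; others in the source may bear on it.

Compound 1 `Cn1ncc(Cl)c1-c1cc(C(=O)N[C@@H]2CN[C@H](CCN3CCCCC3)C[C@H]2c2ccc(Cl)c(Cl)c2)oc1Cl` is the reference point of these notes. In an assay for inhibition of RAC-alpha serine/threonine-protein kinase (Homo sapiens), read by HTRF, with a stated time of 1 h (on this read-out higher numbers stand for weaker inhibition and lower numbers for stronger inhibition), compound 1 gives 5.65 nM. That is the only number shown in this assay so far; the remaining entry is the limit of > 1000 nM in this assay, at which 1 of the 2 values shown sits. Compound 2 `O=C(N[C@@H]1CNCC[C@H]1c1ccc(Cl)cc1)c1ccc(-c2ncnc3c2CCC3O)s1` differs from compound 1 in several places at once. In this assay, going by the values given here, compound 2 gives > 1000 nM, which is a limit of the assay and not a number, so compound 2 offers no measured step against compound 1.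

Compound 3 `CCC[C@@H]1C[C@@H](c2ccc(Cl)c(Cl)c2)[C@H](NC(=O)c2cc(-c3c(Cl)cnn3C)c(Cl)o2)CN1` differs from compound 1 in exactly one place: methyl in place of piperidin-1-yl on a saturated chain carbon, two bonds along the chain from a saturated ring carbon, which cut one bond further out reads 2-(piperidin-1-yl)ethyl to propyl. Among the compounds with values here, no measured pair carries this change, so the size of the step cannot be read off the data and has to be estimated. The expectation is a loss in this assay of moderate size, beyond the usual scatter, as the estimated step of a 5.3-fold higher number from compound 1 to compound 3 (0.73 log units; beyond the scatter) expresses. Compound 3 is therefore expected at 30 nM in this assay, with an estimated range from 6 nM to 150 nM.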

Compound 3, half-maximal inhibitory concentration: 10.4 nM
For compound 3 the middle estimate is 2.9-fold (0.46 log units) above the measured one; the range from low to high includes it.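

Cutting the 2-(piperidin-1-yl)ethyl substituent back to propyl gives, in this assay, a 1.8-fold higher number from compound 1 to compound 3 (0.26 log units; within the scatter). On this one pair, the piperidin-1-yl group, with its ring nitrogen, is therefore not required for a low number in this assay at this position: a plain methyl on the same saturated chain carbon, two bonds along the chain from a saturated ring carbon, reads within the scatter of the parent. Nothing measured here bears on why the two compounds read alike, and this single pair gives no trend along the chain.

The compounds shown leave open whether the propyl chain itself contributes, since the series as given has no member with a shorter chain or with hydrogen on that saturated ring carbon. Also open, as far as these compounds go, is how far the position tolerates other end groups, such as a primary amine, a carboxylic acid or a morpholine ring at the chain end, or a longer chain such as butyl or pentyl.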